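The compounds below may be only part of what the source reports. "The series", "measured", "known", "first", "only" and "open" are said of these compounds alone.

Of the compounds shown here, three of the same core have been measured in a functional assay on HT-29 cells (Homo sapiens) for inhibition, read by sulforhodamine B assay, with a stated time of 48 h; a lower number here means a stronger inhibitor of growth, a higher number a weaker inhibitor of growth. Compound 1 `CCOC(=O)C1=C(C)NC(=O)NC1c1ccc(SC)cc1` gives 10.2 ug/mL in this assay, and compound 2 `CCOC(=O)C1=C(C)NC(=S)NC1C1CCCCC1` gives 25.2 ug/mL. Compound 3 `CCOC(=O)C1=C(C)NC(=S)NC1c1ccc(O)cc1` has only a limit in this assay, > 250 ug/mL, and it sits at the limit of > 250 ug/mL in this assay, at which 1 of the 3 values shown sits. Compound 3 therefore stands at the weak end of the values shown, with no number of its own. Compound 4 `CCOC(=O)C1=C(C)NC(=S)NC1c1ccc(O)c(O)c1` differs from compound 3 by hydroxy in place of hydrogen on an aromatic carbon. For the measured compounds named here, no step between measured compounds resembles this change, so it offers no guide. Compound 4 is expected to remain near the limit, with a step of a number no higher from compound 3 to compound 4 (the limit leaves the size open) that amounts to none beyond the scatter. For compound 4 the estimate is 250 ug/mL, ranging from 80 ug/mL to 500 ug/mL, and most likely reported again only as a limit.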

Compound 4, concentration for 50% growth inhibition: 33.7 ug/mL
For compound 4 the middle estimate is 7.4-fold (0.87 log units) above the measured one; the whole stated range lies above it.
By their numbers in this assay, from the lowest: compound 1; then compounds 2 and 4 (each within the scatter of the next). At a limit, above all of these: compound 3.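

In this assay, hydroxy in place of hydrogen on an aromatic carbon, ortho to a hydroxy group, gives an at least 7.4-fold lower number from compound 3 to compound 4 (0.87 log units; beyond the scatter), the only single-place step among these compounds. For the compounds shown here, this aromatic carbon therefore responds to substitution in a way the earlier compounds could not show. Compound 3 has only a limit, so the step has a floor and no full size: the limit of > 250 ug/mL in this assay, at which 1 of the 4 values shown sits.

As far as these compounds go, whether a methoxy group, a chlorine atom or an amine on this same carbon would give a similar step remains open. So does the outcome of this hydroxy with the other hydroxy group absent.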